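The compounds below may be only part of what the source reports. "The series", "measured", "known", "first", "only" and "open" are said of these compounds alone.

Measured compounds:
compound 1 `Nc1ncnc2c1c(-c1ccc(Oc3ccccc3)cc1)cn2C[C@H]1CCCN1C(CO)CO`: 14500 nM
compound 2 `Nc1ncnc2c1c(-c1cnc3[nH]ccc3c1)cn2[C@H]1CCN(C[C@@H]2CO2)C1`: 9440 nM
compound 3 `Nc1ncnc2c1c(-c1ccc(Oc3ccccc3)cc1)cn2C[C@H]1CCCN1C[C@@H](O)CO`: 9540 nM

In a functional assay on JeKo-1 cells (Homo sapiens) for antiproliferative activity (a lower number here means a stronger inhibitor, a higher number a weaker inhibitor), compound 1 gives 14500 nM, the highest of the three numbers, yet compound 3 and compound 2 both lie within the usual scatter of it, so none of the three can be called stronger or weaker than another. Going by the values given here, the only step between compounds that differ in one place, a 1.5-fold lower number from compound 1 to compound 3 (0.18 log units; within the scatter), is small. Compound 4 `Nc1ncnc2c1c(-c1ccc(Oc3ccccc3)cc1)cn2[C@H]1CCN(C[C@@H]2CO2)C1` has not yet been measured. It differs from compound 1 in one place: 1-((oxiran-2-yl)methyl)pyrrolidin-3-yl in place of (1-(2-hydroxy-1-(hydroxymethyl)ethyl)pyrrolidin-2-yl)methyl on an aromatic nitrogen. Among the compounds with values here, no measured step covers this exact change. Compound 2 carries the same group that enters here, attached to a different aromatic group, and in this assay compound 2 gives 9440 nM. Compound 1 and compound 3 share the aromatic group of compound 4 and give numbers of the same order. Since all three measured numbers sit close together, no step beyond the scatter is expected for compound 4. Compound 4 is therefore estimated at 10000 nM, with a range from 3000 nM to 30000 nM. For compound 4 the expected step of a 1.5-fold lower number from compound 1 to compound 4 (0.16 log units; within the scatter) stays within the scatter.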

Compound 4, half-maximal inhibitory concentration: 1480 nM
Compound 4: the middle estimate sits 6.8-fold (0.83 log units) above what was measured; the whole stated range lies above it.
By their numbers in this assay, from the lowest: compound 4; then compounds 2, 3 and 1 (each within the scatter of the next).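

In this assay, this position on the aromatic nitrogen proves able to move the number beyond the scatter, with a 9.8-fold lower number from compound 1 to compound 4 (0.99 log units; beyond the scatter) and a 6.4-fold lower number from compound 3 to compound 4 (0.81 log units; beyond the scatter). The swap is not a single small edit: the diol side chains leave, the attached ring changes from pyrrolidin-2-ylmethyl to pyrrolidin-3-yl, and an oxirane ring enters, so these steps cannot assign the gain to any one part. The entering group does not give a low number on every aromatic group, as compound 2 carries it at 9440 nM while compound 4 gives 1480 nM.

No supporting data explain why this change lowers the number. On these data alone, it also remains open whether the oxirane ring itself is needed, or whether a plain methyl or an acrylamide on the same pyrrolidine nitrogen would give a similar number.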